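The source may report more compounds than this note shows. Statements on the series, on what has been measured and on what is new or still open speak of the compounds shown alone.

Compound 1 `CC(O)(CSc1cccc(C(F)(F)F)c1)C(=O)Nc1ccc(S(F)(F)(F)(F)F)cc1` and compound 2 `CC(O)(CSc1ccccc1C(F)(F)F)C(=O)Nc1ccc(S(F)(F)(F)(F)F)cc1` share a core and differ in one place: 2-(trifluoromethyl)phenyl in place of 3-(trifluoromethyl)phenyl on a sulfur. In a functional assay on CWR22R cells (Homo sapiens) for antiproliferative activity, read by propidium iodide staining, with a stated time of 96 h (a higher number here means a weaker inhibitor, a lower number a stronger inhibitor), compound 1 gives 23400 nM, and compound 2 gives 13200 nM; the step is a 1.8-fold lower number from compound 1 to compound 2 (0.25 log units; within the scatter). Compound 3 `CC(O)(CS(=O)(=O)c1cccc(C(F)(F)F)c1)C(=O)Nc1cccc(S(F)(F)(F)(F)F)c1` gives 24600 nM in this assay; how its core differs from that of compound 1 is not broken down here. Compound 4 `CC(O)(CS(=O)(=O)c1ccccc1C(F)(F)F)C(=O)Nc1cccc(S(F)(F)(F)(F)F)c1` stands to compound 3 as compound 2 stands to compound 1: 2-(trifluoromethyl)phenyl in place of 3-(trifluoromethyl)phenyl on a sulfonyl sulfur. This is the same kind of change, not the same one, since in the earlier pair the place is on a sulfur whose other neighbours are a saturated chain carbon, whereas here it is on a sulfonyl sulfur. Because the earlier step was a 1.8-fold lower number from compound 1 to compound 2 (0.25 log units; within the scatter), a step of similar size, a 1.8-fold lower number from compound 3 to compound 4 (0.24 log units; within the scatter), is expected from compound 3 to compound 4 in this assay. Compound 4 is therefore estimated at 14000 nM, with a range of 6500 nM to 30000 nM.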

Compound 4, half-maximal inhibitory concentration: 27700 nM
Compound 4: the middle estimate sits 2.0-fold (0.30 log units) below what was measured; measured number inside the range.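

In this assay, 2-(trifluoromethyl)phenyl in place of 3-(trifluoromethyl)phenyl on a sulfonyl sulfur gives a 1.1-fold higher number from compound 3 to compound 4 (0.05 log units; within the scatter). Set beside the same change on the other core, the two steps do not separate: the same change on two cores in this assay, a 1.8-fold lower number (0.25 log units; within the scatter) from compound 1 to compound 2 and a 1.1-fold higher number (0.05 log units; within the scatter) from compound 3 to compound 4, 2.0-fold (0.30 log units) apart, within the scatter of two such steps. On these two pairs the change stays within the scatter on both cores, but this does not show that a real effect carries from one core to the other, as neither step is shown to be an effect at all.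

Open, on these data alone, is whether any replacement on this ring moves the number beyond the scatter, for example a nitrile or a methoxy group in place of trifluoromethyl. Also open, as far as these compounds go, is how the sulfur and sulfonyl forms compare on an otherwise identical core.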